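Swapping dichlorophenyl for dimethylphenyl on a piperazine-linked quinazoline

The source may hold more compounds than are shown below. What is called first, only, known or untested is meant among the compounds shown, and "the series" means these compounds.

Three compounds have been measured in a functional assay on HCT-116 cells (Homo sapiens) for cytotoxicity, read by MTT assay, with a stated time of 2 days, tested at 10 uM; a lower number here means less inhibition, a higher number more inhibition at the concentration tested (going by the name of the read-out):

Compound 1, `Cc1cccc(N2CCN(CCCNc3nc(NCc4ccco4)c4ccccc4n3)CC2)c1C`, gives 93.2%.
Compound 2, `Clc1cccc(N2CCN(CCCNc3nc(NCc4ccco4)c4ccccc4n3)CC2)c1Cl`, gives 94.5%.
Compound 3, `Clc1cccc(N2CCN(CCCCNc3nc(NCc4ccco4)c4ccccc4n3)CC2)c1Cl`, gives 94.7%.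

All three numbers sit close together, and none of the gaps between them is larger than the usual scatter of this kind of measurement. Compound 4, `Cc1cccc(N2CCN(CCCCNc3nc(NCc4ccco4)c4ccccc4n3)CC2)c1C`, has not yet been measured. The cores of compound 2 and compound 3 differ, but that difference is not broken down here. Going from compound 2 to compound 1 the change is 2,3-dimethylphenyl in place of 2,3-dichlorophenyl on an amine nitrogen in a ring, and it produced a number 1.3 percentage points lower from compound 2 to compound 1 (within the scatter). The very same change, (2,3-dimethylphenyl in place of 2,3-dichlorophenyl on an amine nitrogen in a ring), turns compound 3 into compound 4, on the same kind of ring atom with the same surroundings. Since the earlier instance left the read-out essentially unchanged, the step expected for a number 1.2 percentage points lower from compound 3 to compound 4 (within the scatter) rests on that one pair and should likewise be small, because a number 1.3 percentage points lower from compound 2 to compound 1 (within the scatter) stayed within the scatter. Compound 4 is therefore estimated at 93.5%, likely falling between 87% and 98%.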

Compound 4, a percentage reported as inhibition, at one concentration (the size of the read-out at that concentration, not a potency): 94.3%
Estimate against measurement, compound 4: 0.8 percentage points below, and the stated range covers the measured number.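

In this assay, putting 2,3-dimethylphenyl in place of 2,3-dichlorophenyl gives a number 0.4 percentage points lower from compound 3 to compound 4 (within the scatter). Each reading gives the size of the effect at one concentration only, so the two groups cannot be compared at any other concentration, and two cores cannot show how the change would behave on a third. What the data do show is that this swap left the read-out about the same on both cores, with no measurable difference between the two steps: the same change on two cores in this assay, a number 1.3 percentage points lower (within the scatter) from compound 2 to compound 1 and a number 0.4 percentage points lower (within the scatter) from compound 3 to compound 4, 0.9 percentage points apart, within the scatter of two such steps

The compounds shown leave open whether a group of a different kind on the same ring nitrogen, such as an unsubstituted phenyl or a phenyl carrying a carboxylic acid, would move the read-out beyond the scatter. They also leave open whether a shorter chain to the shared core would keep the read-out where it stands, and whether any of these differences would appear at a lower concentration.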